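A few compounds are considered here, and "the series" means these few. Any claim that something is new, unique, unknown or untested is made for them only; others in the source may bear on it.

In an ADME assay on microsomes from liver (Homo sapiens) for metabolic stability, read by LC-MS, with a stated time of 30 min, tested at 1 uM (a higher number here means that more of the compound is left, a lower number that less of the compound is left), compound 3 `Cc1cccc(S(=O)(=O)c2ccc(CNC(=O)c3cc4cnccc4[nH]3)cc2)c1` gives 49%, the lowest of the three measured numbers. Compound 1 `O=C(NCc1ccc(S(=O)(=O)c2cccc(C(F)(F)F)c2)cc1)c1cc2cnccc2[nH]1` gives 81%. Compound 2 `O=C(NCc1ccc(S(=O)(=O)c2cc(F)cc(F)c2)cc1)c1cc2cnccc2[nH]1` gives 82%. These two differ by a number 1 percentage points higher from compound 1 to compound 2 (within the scatter). Compound 4 `O=C(NCc1ccc(S(=O)(=O)c2ccc(F)cc2)cc1)c1cc2cnccc2[nH]1` changes the group on the sulfonyl sulfur: 4-fluorophenyl in place of 3-methylphenyl on a sulfonyl sulfur. For the measured compounds named here, two measured steps bear on this change, a number 32 percentage points lower from compound 1 to compound 3 (beyond the scatter) and a number 33 percentage points lower from compound 2 to compound 3 (beyond the scatter). Going by the values given here, each leads to the 3-methylphenyl group of compound 3 from a ring carrying fluorine, yet no measured compound carries 4-fluorophenyl, so a somewhat smaller rise is expected in this assay. The expected change is a number 25 percentage points higher from compound 3 to compound 4 (beyond the scatter). For compound 4 the estimated value is 74%, with an expected range of 58% to 88%.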

Compound 4, percent of the compound remaining: 91%
Compound 4: the middle estimate sits 17 percentage points below what was measured, outside the stated range (above it).
By their numbers in this assay, from the lowest: compound 3; then compounds 1, 2 and 4 (each within the scatter of the next).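

In this assay the swap on the sulfonyl sulfur gives a number 42 percentage points higher from compound 3 to compound 4 (beyond the scatter) and so shows that a single fluorine in 4-fluorophenyl is enough to leave 3-methylphenyl behind by a large margin. The other two steps, a number 9 percentage points higher from compound 2 to compound 4 (within the scatter) and a number 10 percentage points higher from compound 1 to compound 4 (within the scatter), place 4-fluorophenyl level with both earlier rings, so all three fluorine-bearing rings form one group, with compound 3 alone lower. Nothing available explains this difference. Still open, on these data alone, is how a plain phenyl ring would behave at this position, and whether a methoxy group or an amine on the ring would keep compound 4's standing.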